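This account rests on a few compounds, and the source may have more. Where it says the series, first, only, none or still open, it means among the compounds named here.

For the measured compounds named here, compound 1 `C=CCc1cc(C(C)=O)c(O)cc1OCCCCCCCCCCC#N` is one of three compounds measured in an assay on isolated protein for inhibition of leukotriene B4 receptor 1 (Homo sapiens), tested at 10 uM; on this read-out higher numbers stand for more inhibition at the one concentration tested (going by the name of the read-out) and lower numbers for less inhibition. In this assay compound 1 gives 50%, the lowest of the three numbers. Compound 2 `CCc1cc(C(C)=O)c(O)cc1OCCCC(C)(C)C(=O)O` gives 89%, and compound 3 `CCc1cc(C(C)=O)c(O)cc1OCCCC(C)(C)c1nnn[nH]1` gives 100%; both stand beyond the scatter above compound 1. Going by the values given here, the one step between compounds that differ in a single place runs a number 11 percentage points higher from compound 2 to compound 3 (beyond the scatter).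

Compound 4 `C=CCc1cc(C(C)=O)c(O)cc1OCCCCCC(C)(C)O` is not yet measured. It differs from compound 1 in one place: 1-hydroxy-1-methylethyl in place of 5-cyanopentyl on a saturated chain carbon, five bonds along the chain from an oxygen on an aromatic ring. The group that leaves carries no hydrogen-bond donor, while the group that enters carries one; the chain also becomes shorter, as the counts of heavy atoms show.

Among the compounds with values here, no measured step bears directly on this change. The step from compound 2 to compound 3 swaps a carboxy group for a 1H-tetrazol-5-yl group, a different part of the molecule and a different kind of group, so it gives no guide to what a 1-hydroxy-1-methylethyl group in place of a 5-cyanopentyl group does. The expectation for compound 4 therefore rests on compound 1 alone, and no step beyond the scatter is expected in either direction, with wide uncertainty.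

Compound 4 is expected to give about 45%, within a range from 15% to 80%, which would be a step of a number 5 percentage points lower from compound 1 to compound 4 (within the scatter).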

Compound 4, a percentage reported as inhibition, at one concentration (the size of the read-out at that concentration, not a potency): 98%
For compound 4 the middle estimate is 53 percentage points below the measured one, and the stated range ends below it.
By their numbers in this assay, from the lowest: compound 1; then compounds 2, 4 and 3 (each within the scatter of the next, the first and the last beyond it).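

In this assay, this single swap on the saturated chain carbon, five bonds along the chain from an oxygen on an aromatic ring, gives a number 48 percentage points higher from compound 1 to compound 4 (beyond the scatter), so the read-out responds strongly to what stands at this place while the rest of the molecule stays the same. The change replaces 5-cyanopentyl, with 7 heavy atoms and 0 hydrogen-bond donors, by 1-hydroxy-1-methylethyl, with 4 heavy atoms and 1 hydrogen-bond donor, which shows that the longer nitrile-bearing group is not needed for a high number in this read-out. Nothing available explains the size of this step.

The shorter chain and the new hydroxyl group arrive together, so the compounds shown leave open which of the two changes carries the step, or whether both are needed. A chain of the same length ending in a plain methyl group in place of the hydroxyl, or the longer chain of compound 1 ending in a hydroxyl or a primary amine in place of the nitrile, would begin to pull these two changes apart.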